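Series notes: fluoro to trifluoromethyl on the benzyl group

The compounds below may be only part of what the source reports. "The series", "measured", "known", "first", "only" and "open" are said of these compounds alone.

In a functional assay on RAW264.7 cells (Mus musculus) for inhibition, read by Griess assay, with stated times of 2 h and 24 h (a lower number here means a stronger inhibitor, a higher number a weaker inhibitor), compound 2 `COc1ccc([C@@H]2CC(=O)c3c(O)cc(OCc4cn(Cc5ccc(F)cc5)nn4)cc3O2)cc1O` gives 15100 nM. Compound 1 `CCn1cc(COc2cc(O)c3c(c2)O[C@H](c2ccc(OC)c(O)c2)CC3=O)nn1` gives 15000 nM and compound 3 `COc1ccc([C@@H]2C/C(=N\O)c3c(O)cc(OCc4cn(Cc5ccccc5C)nn4)cc3O2)cc1O` gives 18000 nM, so compound 2 sits among the three numbers with each neighbour within the scatter. For the measured compounds named here, the one measured step at this part of the molecule, a 1.0-fold higher number from compound 1 to compound 2 (0.00 log units; within the scatter), left the number unchanged. Compound 4 `COc1ccc([C@@H]2CC(=O)c3c(O)cc(OCc4cn(Cc5ccc(C(F)(F)F)cc5)nn4)cc3O2)cc1O` differs from compound 2 by trifluoromethyl in place of fluoro on an aromatic carbon. Going by the values given here, no measured compound carries trifluoromethyl, so the only guidance is that the earlier change on this benzyl carbon produced nothing beyond the scatter. The expected step is therefore a 1.0-fold lower number from compound 2 to compound 4 (0.00 log units; within the scatter), not beyond the scatter. Compound 4 is estimated at 15000 nM, with a range from 7500 nM to 30000 nM.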

Compound 4, half-maximal inhibitory concentration: 17700 nM
For compound 4 the middle estimate is 1.2-fold (0.07 log units) below the measured one; measured number inside the range.
By their numbers in this assay, from the lowest: compounds 1, 2, 4 and 3 (each within the scatter of the next).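

In this assay, for the compounds shown here, trifluoromethyl in place of fluoro gives a 1.2-fold higher number from compound 2 to compound 4 (0.07 log units; within the scatter) and stays within the scatter, the first reading of a change on the aromatic carbon of the benzyl group itself. The wider change, 4-(trifluoromethyl)phenyl in place of methyl on the chain carbon, gives a 1.2-fold higher number from compound 1 to compound 4 (0.07 log units; within the scatter) and also stays within the scatter, so this substituent has not yet separated from the small alkyl end of the series. No measurement at hand explains this flat response.

Going by these compounds, whether an amine or a carboxylic acid on the benzyl group would move the number beyond the scatter stays open. On these data alone, a longer chain between the aromatic nitrogen and the benzyl group is equally open.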